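A few compounds are considered here, and "the series" means these few. Any claim that something is new, unique, unknown or untested is made for them only; others in the source may bear on it.

In a functional assay on L1210 cells (Mus musculus) for antiproliferative activity, read by cell counting, with a stated time of 2 days (a higher number here means a weaker inhibitor, a lower number a stronger inhibitor), compound 1 (`COc1cc(C(=O)c2sc(N(C)C)nc2N)cc(OC)c1OC`) gives 11000 nM. Compound 2 (`COc1cc(C(=O)c2sc(N(C)Cc3ccccc3)nc2N)cc(OC)c1OC`) is reported as > 200000 nM, which is a limit of the assay and not a number. Compound 2 therefore has no exact place on the scale and stands only at that limit.

Compound 3 (`COc1cc(C(=O)c2sc(N3CCCC3)nc2N)cc(OC)c1OC`) is reached from compound 2 by putting pyrrolidin-1-yl in place of benzyl(methyl)amino on an aromatic carbon. Going by the values given here, one measured step bears on this change, namely an at least 18-fold higher number from compound 1 to compound 2 (1.25 log units; beyond the scatter). That step is large and beyond the scatter, and it came with phenyl in place of hydrogen on a saturated chain carbon bound to a nitrogen on an aromatic ring.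

Compound 3 carries no such phenyl, so a large drop in this assay is expected, back towards compound 1 at 11000 nM. The expected change is an at least 20-fold lower number from compound 2 to compound 3 (1.30 log units; beyond the scatter), towards a stronger inhibitor. For compound 3 the estimated value is 10000 nM, with an expected range from 2500 nM to 40000 nM.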

Compound 3, half-maximal inhibitory concentration: 370 nM
Estimate against measurement, compound 3: 27-fold (1.43 log units) above; measured number outside the range, below it.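

Going by these compounds alone, at this aromatic carbon, next to the ring nitrogen and next to the ring sulfur, the earlier compounds showed only a loss on going from dimethylamino to a larger amino group, whereas pyrrolidin-1-yl in place of dimethylamino gives a 30-fold lower number from compound 1 to compound 3 (1.47 log units; beyond the scatter) in this assay, so a larger amino group here can also bring a gain. Compound 2 is reported at > 200000 nM, which is a limit of the assay and not a number. Pyrrolidin-1-yl in place of benzyl(methyl)amino gives an at least 540-fold lower number from compound 2 to compound 3 (2.73 log units; beyond the scatter), and the size of this step is only a bound, because one of its ends is that limit: the limit of > 200000 nM in this assay, at which 1 of the 3 values shown sits.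

The compounds shown leave open whether the gain follows from having the amino nitrogen in a ring at all or from this five-membered ring in particular, a question that azetidin-1-yl, piperidin-1-yl or morpholin-4-yl at the same carbon would address. They also leave open whether an open-chain diethylamino group would stand nearer to dimethylamino or to pyrrolidin-1-yl.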